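This account rests on a few compounds, and the source may have more. Where it says the series, first, only, none or still open, it means among the compounds named here.

Three compounds sharing one core were measured in an ADME assay on MT4 cells (Homo sapiens) for cytotoxicity, read by MTT assay, with a stated time of 96 h; a higher number here means that more compound is tolerated, a lower number that less compound is tolerated. Compound 1 `Cn1c(-c2ccc(NC(=O)CN3CCCCC3)cc2)nc2cc(C(F)(F)F)ccc21` gives 9000 nM in this assay, compound 2 `O=C(CCl)Nc1ccc(-c2nc3cc(C(F)(F)F)ccc3[nH]2)cc1` gives 5000 nM, and compound 3 `COc1cc(OC)cc(-c2nc3cc(C(F)(F)F)ccc3[nH]2)c1` gives 19000 nM. Compound 2 sits at the low end of these three numbers: its gap to compound 1 lies within the usual scatter, whereas compound 3 tolerates a clearly larger amount, beyond the scatter. Compound 4 `O=[N+]([O-])c1ccc(-c2nc3cc(C(F)(F)F)ccc3[nH]2)cc1` has not yet been measured in this assay. It differs from compound 2 in one place: nitro in place of ((chloromethyl)carbonyl)amino on an aromatic carbon. Among the compounds with values here, no measured pair shows this change, so no step for it is known. The three numbers fall in a narrow band. Compound 4 is therefore expected to stay in that band, with a step of a 1.6-fold higher number from compound 2 to compound 4 (0.20 log units; within the scatter) that should not exceed the scatter. The estimate for compound 4 in this assay is 8000 nM, between 3000 nM and 25000 nM.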

Compound 4, half-maximal cytotoxic concentration: 6000 nM
For compound 4 the middle estimate is 1.3-fold (0.12 log units) above the measured one; measured number inside the range.
By their numbers in this assay, from the lowest: compounds 2, 4 and 1 (each within the scatter of the next); then compound 3.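

Within the data shown here, on an aromatic carbon para to a large group, nitro in place of ((chloromethyl)carbonyl)amino in this assay gives a 1.2-fold higher number from compound 2 to compound 4 (0.08 log units; within the scatter) and so provides the first known step for this change. Replacing that chlorine-bearing group, which carries a hydrogen-bond donor, with nitro, which carries none, therefore does not separate the two compounds in this assay. From the compounds shown here alone, whether an amine or a carboxylic acid at this position would also stay within the scatter of compound 2 remains open. No measurement shown here offers an explanation for this result.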